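From an Acetyl Group to an Amide on the Shared Core

The compounds below may be only part of what the source reports. "The series", "measured", "known", "first", "only" and "open" are said of these compounds alone.

Compound 1 `O/N=C(/Nc1cccc(Cl)c1)c1ccc2occc2c1` and compound 2 `O/N=C(/Nc1cccc(C(F)(F)F)c1)c1ccc2occc2c1` share a core with compound 3 `CC(=O)c1cccc(N/C(=N/O)c2ccc3occc3c2)c1` and differ from it only in the group on one aromatic carbon. In an assay on isolated protein for inhibition of Indoleamine 2,3-dioxygenase 1 (Homo sapiens), read by spectrophotometry (a lower number here means a stronger inhibitor, a higher number a weaker inhibitor), compound 1 gives 690 nM. In the same assay compound 2 gives 1200 nM. Compound 3 reaches no number in this assay: its value of > 30000 nM is a limit (the limit of > 30000 nM in this assay, at which 1 of the 3 values shown sits), and compound 3 therefore stands at the weak end of the three. The steps of an at least 43-fold higher number from compound 1 to compound 3 (1.63 log units; beyond the scatter) and an at least 25-fold higher number from compound 2 to compound 3 (1.39 log units; beyond the scatter) both show a large loss on going to acetyl, while a 1.7-fold higher number from compound 1 to compound 2 (0.24 log units; within the scatter) made no difference that the scatter can resolve.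

Compound 4 `O=C(NCC1CCCCC1)c1cccc(N/C(=N/O)c2ccc3occc3c2)c1` is built from compound 3 by one change: (cyclohexylmethyl)amino in place of methyl on a carbonyl carbon. For the measured compounds named here, none of the measured steps alters the carbonyl carbon in this way, so there is no step of the same kind to lean on; the only guidance is where compound 3 stands. The carbonyl itself remains in compound 4, and a carbonyl-bearing group marks the weak compound in both an at least 43-fold higher number from compound 1 to compound 3 (1.63 log units; beyond the scatter) and an at least 25-fold higher number from compound 2 to compound 3 (1.39 log units; beyond the scatter). Compound 4 is therefore expected to remain weak, with an estimate of 20000 nM lying between 3000 nM and 100000 nM. This estimate means an expected step of an at least 1.5-fold lower number from compound 3 to compound 4 (0.17 log units; that floor lies within the scatter), and a further limit rather than a number is quite possible.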

Compound 4, half-maximal inhibitory concentration: > 30000 nM
Compound 4: a limit, no number; the forecaster's own chance of this, stated with the estimate: 50%; at least 1.5-fold (0.17 log units) between middle value and limit.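

In this assay compound 4 gives > 30000 nM, which is a limit and not a number. Compound 3 also stands at a limit, so no step can be read between compound 3 and compound 4: the limit of > 30000 nM in this assay, at which 2 of the 4 values shown sit.

The compounds shown leave open whether (cyclohexylmethyl)amino in place of methyl on a carbonyl carbon changes inhibition at all, and in which direction.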